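The source may hold more compounds than are shown below. What is called first, only, known or untested is meant among the compounds shown, and "the series" means these compounds.

Three compounds of the series have been run in a functional assay on A498 cells (Homo sapiens) for inhibition, read by sulforhodamine B assay, with a stated time of 48 h; a higher number here means a weaker inhibitor, a lower number a stronger inhibitor. Compound 1 `O=C(Nc1cccc(-n2cc(-c3ccncc3)c(-c3ccc(Cl)c(O)c3)n2)c1)Nc1cccc(C(F)(F)F)c1` gives 2240 nM; compound 3 `COc1cc(-c2nn(-c3cccc(NC(=O)Nc4cccc(C(F)(F)F)c4)c3)cc2-c2ccncc2)ccc1Cl` gives 960 nM; compound 2 `COc1cc(-c2nn(-c3cccc(NC(=O)Nc4cc(C(F)(F)F)cc(C(F)(F)F)c4)c3)cc2-c2ccncc2)ccc1Cl` gives 610 nM. Compound 2 has the lowest of the three numbers, but its gap to compound 3, a 1.6-fold higher number from compound 2 to compound 3 (0.20 log units; within the scatter), is within the scatter, so the two cannot be ordered; only compound 1 stands clearly apart from it.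

Compound 4 `O=C(Nc1cccc(-n2cc(-c3ccncc3)c(-c3ccc(Cl)c(O)c3)n2)c1)Nc1cc(C(F)(F)F)cc(C(F)(F)F)c1` is compound 2 with one change: hydrogen in place of methyl on an oxygen on an aromatic ring. The same difference, taken in the other direction, is the step from compound 1 to compound 3, a 2.3-fold lower number from compound 1 to compound 3 (0.37 log units; beyond the scatter), a modest move beyond the scatter. The bis(trifluoromethyl)phenyl urea end of compound 2 and compound 4 is unchanged by this step; the step from compound 2 to compound 3 shows that swapping one trifluoromethyl for hydrogen on that ring moves the number only within the scatter, so the methoxy-to-hydroxy change should carry most of whatever shift appears.

On this basis, compound 4 is expected to give a higher number than compound 2, with a step of about a 2.3-fold higher number from compound 2 to compound 4 (0.36 log units; beyond the scatter) in this assay. The estimate for compound 4 is 1400 nM, with a range of 700 nM to 2800 nM.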

Compound 4, half-maximal inhibitory concentration: 790 nM
Compound 4: middle estimate off by 1.8-fold (0.25 log units), on the high side; the range from low to high includes it.
By their numbers in this assay, from the lowest: compounds 2, 4 and 3 (each within the scatter of the next); then compound 1.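

Hydroxy in place of methoxy on the core of compound 2 gives a 1.3-fold higher number from compound 2 to compound 4 (0.11 log units; within the scatter), so the change that stood beyond the scatter on the core of compound 1 stays within it here, although the two steps themselves cannot be separated: the same change on two cores in this assay, a 2.3-fold lower number (0.37 log units; beyond the scatter) from compound 1 to compound 3 and a 1.3-fold lower number (0.11 log units; within the scatter) from compound 4 to compound 2, 1.8-fold (0.26 log units) apart, within the scatter of two such steps

Trifluoromethyl in place of hydrogen on the urea's outer aromatic ring gives a 2.8-fold lower number from compound 1 to compound 4 (0.45 log units; beyond the scatter), which puts this change beyond the scatter on the hydroxy core, while on the methoxy core it stays within it, and again the two steps cannot be separated: the same change on two cores in this assay, a 1.6-fold higher number (0.20 log units; within the scatter) from compound 2 to compound 3 and a 2.8-fold higher number (0.45 log units; beyond the scatter) from compound 4 to compound 1, 1.8-fold (0.26 log units) apart, within the scatter of two such steps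

Either change alone, methyl on the oxygen or the added trifluoromethyl, therefore brings compound 1 into the group formed by compound 2, compound 3 and compound 4, and adding the second change to that group shows no further step beyond the scatter.

On these data alone, only hydrogen and methyl appear on this oxygen, so the effect of an ethyl or longer chain there, or of an amine in place of the hydroxy, stays open. Also open, as far as these compounds go, is whether this grouping holds in any cell line other than the one used here.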